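Replacing the hepta-1,3-dien-1-yl chain in compound 1

The source may hold more compounds than are shown below. What is called first, only, known or untested is meant among the compounds shown, and "the series" means these compounds.

Going by the values given here, compound 1 `CCC/C=C/C=C/c1cc(C#N)ccc1COC(c1ccc(C#N)cc1)c1cncn1C` is the one compound with a measured number in a functional assay on NIH3T3 cells (Mus musculus) (a lower number here means that less compound is needed, a higher number that more compound is needed for the effect), where compound 1 gives 16.7 nM. Compound 2 `Cn1cncc1C(OCc1ccc(C#N)cc1-c1ccc(C#N)cc1)c1ccc(C#N)cc1` reaches only the limit of this assay, < 0.1 nM. The step of an at least 160-fold lower number from compound 1 to compound 2 (2.22 log units; beyond the scatter) is large; see also (the limit of < 0.1 nM in this assay, at which 1 of the 2 values shown sits). Compound 3 `Cn1cncc1C(OCc1ccc(C#N)cc1C#CC(C)(C)C)c1ccc(C#N)cc1` differs from compound 1 by 3,3-dimethylbut-1-yn-1-yl in place of hepta-1,3-dien-1-yl on an aromatic carbon. Among the compounds with values here, only that step bears on it, and the entering group is not the same, so a smaller change is expected: a 3.3-fold lower number from compound 1 to compound 3 (0.52 log units; beyond the scatter). Compound 3 is estimated to give 5 nM in this assay, within 0.5 nM to 50 nM.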

Compound 3, half-maximal effective concentration: 76.9 nM
Compound 3: middle estimate off by 15-fold (1.19 log units), on the low side; measured number outside the range, above it.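

At this position, replacing the hepta-1,3-dien-1-yl chain does not always lower the number in this assay: 3,3-dimethylbut-1-yn-1-yl goes the opposite way to 4-cyanophenyl, with a 4.6-fold higher number from compound 1 to compound 3 (0.66 log units; beyond the scatter). The gap between the two entering groups is much wider, with an at least 760-fold higher number from compound 2 to compound 3 (2.88 log units; beyond the scatter). The value of compound 2 is a limit, not a number: the limit of < 0.1 nM in this assay, at which 1 of the 3 values shown sits.

As far as these compounds go, whether the low number depends on an aromatic ring here or on 4-cyanophenyl specifically remains open. Also open, from the compounds shown here alone, is how a simple phenyl, an amine or a carboxylic acid would behave at this position.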